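This account rests on a few compounds, and the source may have more. Where it says the series, first, only, none or still open, it means among the compounds named here.

Three compounds share a core in which a phenyl, a trifluoromethyl and a triazole bearing a long fluorinated chain are fixed, and only the group on one aromatic carbon of the core changes. In a functional assay on U-937 cells (Homo sapiens) for cytotoxicity, read by MTT assay, with a stated time of 24 h (on this read-out higher numbers stand for weaker inhibition and lower numbers for stronger inhibition), compound 1 `O=c1c2c(C(F)(F)F)cc(-c3ccccc3)nc2ncn1Cc1cn(CCC(F)(F)C(F)(F)C(F)(F)C(F)(F)C(F)(F)C(F)(F)C(F)(F)C(F)(F)F)nn1` gives only a limit of the assay, > 200 ug/mL. Compound 2 `Cc1nc2nc(-c3ccccc3)cc(C(F)(F)F)c2c(=O)n1Cc1cn(CCC(F)(F)C(F)(F)C(F)(F)C(F)(F)C(F)(F)C(F)(F)C(F)(F)C(F)(F)F)nn1` carries a methyl there and gives 124 ug/mL in this assay. Compound 3 `CCc1nc2nc(-c3ccccc3)cc(C(F)(F)F)c2c(=O)n1Cc1cn(CCC(F)(F)C(F)(F)C(F)(F)C(F)(F)C(F)(F)C(F)(F)C(F)(F)C(F)(F)F)nn1` carries an ethyl, and in this assay compound 3 again gives only a limit, > 200 ug/mL. Compound 3 thus stands at the limit, where two of the three values sit, and no number for it is known.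

Compound 4 `CC(C)c1nc2nc(-c3ccccc3)cc(C(F)(F)F)c2c(=O)n1Cc1cn(CCC(F)(F)C(F)(F)C(F)(F)C(F)(F)C(F)(F)C(F)(F)C(F)(F)C(F)(F)F)nn1` differs from compound 3 by methyl in place of hydrogen on a saturated chain carbon bound to an aromatic carbon and a saturated chain carbon; read one bond further out, the change is ethyl to isopropyl. The nearest measured step is the growth from methyl to ethyl, which gave an at least 1.6-fold higher number from compound 2 to compound 3 (0.20 log units; that floor lies within the scatter), while the earlier change gave an at least 1.6-fold lower number from compound 1 to compound 2 (0.20 log units; that floor lies within the scatter); the step that the two limits leave unreadable from compound 1 to compound 3 is not readable. Given (the limit of > 200 ug/mL in this assay, at which 2 of the 3 values shown sit), the expectation is that compound 4 stays at the limit, with no movement beyond the scatter, so that a number no higher from compound 3 to compound 4 (the limit leaves the size open) is the expected step. Compound 4 is therefore estimated at 200 ug/mL, within 100 ug/mL to 400 ug/mL.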

Compound 4, half-maximal inhibitory concentration: 8.35 ug/mL
Estimate against measurement, compound 4: 24-fold (1.38 log units) above, outside the stated range (below it).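

Isopropyl on this aromatic carbon of the core is the first group in the series to move the read-out beyond the scatter: the single added methyl gives an at least 23-fold lower number from compound 3 to compound 4 (1.37 log units; beyond the scatter), and the same group gives a 15-fold lower number from compound 2 to compound 4 (1.17 log units; beyond the scatter) and an at least 23-fold lower number from compound 1 to compound 4 (1.37 log units; beyond the scatter). Going by these compounds alone, until compound 4, no readable change at this position had gone beyond the scatter, so the earlier compounds gave no sign that it could respond so strongly to so small a change. Nor does the series follow a steady trend with added carbons: ethyl in compound 3 brought no readable gain over methyl in compound 2, whereas the ethyl to isopropyl change in compound 4 did, so only compound 4 stands apart among the four.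

As far as these compounds go, how a cyclopropyl or tert-butyl group, or a straight propyl chain, would read on this carbon remains open, and with it whether the shift follows branching at the saturated chain carbon or isopropyl alone. From the compounds shown here alone, the full size of two of the steps also stays unknown, as each has only a floor set by a limit: the limit of > 200 ug/mL in this assay, at which 2 of the 4 values shown sit.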